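This account rests on a few compounds, and the source may have more. Where it says the series, first, only, none or still open, it means among the compounds named here.

Measured compounds:
Compound 1, `FC(F)(F)c1cccc(-c2cn3ccnc3c(-c3ccc4ncn(C5CCCCC5)c4c3)n2)c1`: 19.9%
Compound 2, `Cc1cccc(-c2cn3ccnc3c(-c3ccc4ncn(Cc5ccccc5)c4c3)n2)c1`: 22.2%

Of the compounds shown here, two have been measured in a functional assay on MCF7 cells (Homo sapiens) for inhibition, read by sulforhodamine B assay, with a stated time of 48 h, tested at 10 uM; on this read-out lower numbers stand for less inhibition and higher numbers for more inhibition at the one concentration tested (going by the name of the read-out). Compound 1, `FC(F)(F)c1cccc(-c2cn3ccnc3c(-c3ccc4ncn(C5CCCCC5)c4c3)n2)c1`, gives 19.9% in this assay. Compound 2, `Cc1cccc(-c2cn3ccnc3c(-c3ccc4ncn(Cc5ccccc5)c4c3)n2)c1`, gives 22.2% in this assay. The two numbers lie within the usual scatter of each other, so compound 2 is not set apart from compound 1 by what has been seen; both read as modest inhibition at the single concentration tested.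

The next compound, compound 3, `c1ccc(Cn2cnc3ccc(-c4nc(-c5cccc6ccccc56)cn5ccnc45)cc32)cc1`, has not yet been measured in this assay. It differs from compound 2 in one place: naphthalen-1-yl in place of 3-methylphenyl on an aromatic carbon

Among the compounds with values here, no step between measured compounds is available, so there is nothing to show how this kind of change has moved the read-out before. Because compound 2 gives 22.2% and compound 1 gives 19.9%, both sitting near each other, the step of a number 3.8 percentage points higher from compound 2 to compound 3 (within the scatter) is expected to be small, none beyond the scatter, if anything a slight rise. Compound 3 is therefore estimated at 26%, with a range from 8% to 46%.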

Compound 3, a percentage reported as inhibition, at one concentration (the size of the read-out at that concentration, not a potency): 29.2%
For compound 3 the middle estimate is 3.2 percentage points below the measured one, and the stated range covers the measured number.
By their numbers in this assay, from the lowest: compounds 1, 2 and 3 (each within the scatter of the next).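

With naphthalen-1-yl in place of 3-methylphenyl on an aromatic carbon of the six-membered aromatic ring with 2 nitrogen, this assay gives the first step read at this position, a number 7 percentage points higher from compound 2 to compound 3 (within the scatter), so the change is not set apart from repeat measurement. The position therefore carries a group of 10 heavy atoms and 2 six-membered aromatic rings of carbon only, where 3-methylphenyl has 7 heavy atoms and one such ring, without a shift beyond the scatter at the single concentration tested. Nothing on hand gives a reason for this result, and the step cannot separate a small real effect from scatter.

From the compounds shown here alone, the two groups compared here are both made of carbon only and have no hydrogen-bond donors or acceptors, so it remains open whether an amine or a carboxylic acid carried at this position would give a read-out beyond the scatter. With a single step and a single concentration, the compounds shown also leave open how these numbers would translate into potency, and whether a smaller group such as methyl would read any differently.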